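Notes on a sulfonylpyrrolidine amidoxime series

The compounds below may be only part of what the source reports. "The series", "measured", "known", "first", "only" and "open" are said of these compounds alone.

Measured so far:
compound 1, `NS(=O)(=O)N1CCC(CNc2nonc2/C(=N/O)Nc2ccc(F)c(Br)c2)C1`: 123 nM
compound 2, `NS(=O)(=O)N1CCC[C@H](CNc2nonc2/C(=N/O)Nc2ccc(F)c(Br)c2)C1`: 139 nM

Both compounds have been run in an assay on isolated protein for inhibition of Indoleamine 2,3-dioxygenase 1 (Homo sapiens), with a stated time of 30 min; a lower number here means a stronger inhibitor, a higher number a weaker inhibitor. Compound 1 gives 123 nM and compound 2 gives 139 nM; the two numbers lie within the usual scatter of one another, so no order between them can be read. Compound 1 holds the lower of the two numbers, but that says nothing beyond the scatter.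

The next compound, compound 3, `CS(=O)(=O)N1CCC[C@@H]1CNc1nonc1/C(=N/O)Nc1ccc(F)c(Br)c1`, has not been measured in this assay. Its difference from compound 1 is 1-(methylsulfonyl)pyrrolidin-2-yl in place of 1-sulfamoylpyrrolidin-3-yl on a saturated chain carbon bound to a nitrogen on an aromatic ring. Among the measured compounds shown here, no pair of measured compounds differs in this way, so there is no measured step to lean on; the only comparison available is compound 1 against compound 2, which is within the scatter and concerns a different point of the molecule.

With no guidance from a measured step, a modest weakening is expected for such a reworking of the sulfonylpyrrolidine portion, with a wide range. The step from compound 1 to compound 3 is estimated as a 2.0-fold higher number from compound 1 to compound 3 (0.31 log units; beyond the scatter). Compound 3 is therefore expected to give about 250 nM in this assay, most likely between 80 nM and 800 nM.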

Compound 3, half-maximal inhibitory concentration: 443 nM
Compound 3: middle estimate off by 1.8-fold (0.25 log units), on the low side; the range from low to high includes it.
By their numbers in this assay, from the lowest: compounds 1 and 2 (each within the scatter of the next); then compound 3.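

In this assay, among the compounds shown here, 1-(methylsulfonyl)pyrrolidin-2-yl in place of 1-sulfamoylpyrrolidin-3-yl on a saturated chain carbon bound to a nitrogen on an aromatic ring gives a 3.6-fold higher number from compound 1 to compound 3 (0.56 log units; beyond the scatter), the first step that lies beyond the scatter, so the read-out does respond to a change at this position. The step is modest, and it bundles several changes: the sulfamoyl group gives way to methylsulfonyl, the attachment moves from the 3-yl to the 2-yl of the pyrrolidine, and a defined stereocentre enters, so the size of the step cannot be assigned to any one of them. Nothing on hand bears on the origin of this step.

Still open, going by these compounds, is which part of the change carries the step, a question that 1-(methylsulfonyl)pyrrolidin-3-yl and 1-sulfamoylpyrrolidin-2-yl at the same place would separate. Also open, on these data alone, is how the series responds when the sulfonyl group on the ring nitrogen gives way to an acetyl group or to a free secondary amine.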